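A few compounds are considered here, and "the series" means these few. Any claim that something is new, unique, unknown or untested is made for them only; others in the source may bear on it.

Measured compounds:
Compound 1, `COc1cccc(N2CCN(C(=O)C(C)N3C(=O)CCC3=O)CC2)c1`, gives 75% in a functional assay on the whole organism (strain Swiss) with Mus musculus as the target, in the maximal electroshock model, with a stated time of 0.25 h, at a dose of 300 mg/kg by the intraperitoneal route; a higher number here means a stronger effect of the compound at the dose given, a lower number a weaker effect.
Compound 2, `CC(C(=O)N1CCN(c2ccc(F)cc2)CC1)N1C(=O)CCC1=O`, gives 100% in this assay.
Compound 3, `CCC(C(=O)N1CCN(c2cccc(C)c2)CC1)N1C(=O)CCC1=O`, gives 100% in this assay.

Compound 3 stands level with compound 2, and the two together hold the highest of the three numbers; compound 1 sits below them by more than the scatter. Among the compounds with values here, the only measured step between neighbours is a number 25 percentage points higher from compound 1 to compound 2 (beyond the scatter), a swap of one aromatic group on the amine nitrogen in the ring; it does not touch the short chain that carries the ring imide.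

Compound 4, `Cc1cccc(N2CCN(C(=O)C(C)N3C(=O)CCC3=O)CC2)c1`, differs from compound 3 by hydrogen in place of methyl on a saturated chain carbon, two bonds along the chain from an amide-type nitrogen in a ring and a carbonyl carbon. Within the data shown here, no measured step bears directly on this change, so the expectation rests on compound 3 alone, whose read-out in this assay is 100%. With nothing to point either way, the step is expected to be none beyond the scatter, estimated as a number 5 percentage points lower from compound 3 to compound 4 (within the scatter). Compound 4 is therefore expected to give about 95%, with a range from 70% to 100%.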

Compound 4, a percentage reported as activity, at one dose (the size of the read-out at that dose, not a potency): 100%
For compound 4 the middle estimate is 5 percentage points below the measured one, within the range that was stated.
By their numbers in this assay, from the lowest: compound 1; then compounds 2, 3 and 4 (each within the scatter of the next).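

In this assay, cutting ethyl to methyl on the saturated chain carbon gives no change at the digits printed from compound 3 to compound 4 (within the scatter), so with the 3-methylphenyl group in place, this position accepts the shorter chain at the dose tested. With the methyl-bearing chain held fixed, the aromatic group gives two different results: 3-methylphenyl in place of 4-fluorophenyl gives no change at the digits printed from compound 2 to compound 4 (within the scatter), whereas methyl in place of methoxy on an aromatic carbon gives a number 25 percentage points higher from compound 1 to compound 4 (beyond the scatter). No available evidence explains either outcome.

The compounds shown leave open how a longer chain, such as propyl, or a phenyl group would behave on the same chain carbon. They also leave open whether a chlorine or a hydroxyl group on the aromatic ring would behave like methyl or like methoxy.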